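Ring size on the core nitrogen, compound 3 to compound 4

The source may report more compounds than this note shows. Statements on the series, on what has been measured and on what is new or still open speak of the compounds shown alone.

The series shares one core and varies the group on an aromatic nitrogen. Compound 1 `CC(C)c1onc(-c2c(Cl)cccc2Cl)c1COc1ccc(-c2nc3ccc(C(=O)O)cc3n2Cc2ccc(F)cc2)cc1` gives 1140 nM in an assay on HEK-293T cells for antagonist activity at vitamin D3 receptor (Homo sapiens), read by a luciferase reporter, with a stated time of 24 h; on this read-out higher numbers stand for weaker inhibition and lower numbers for stronger inhibition; compound 2 `CC(C)c1onc(-c2c(Cl)cccc2Cl)c1COc1ccc(-c2nc3ccc(C(=O)O)cc3n2C2CCCCCC2)cc1` gives 921 nM; compound 3 `CC(C)c1onc(-c2c(Cl)cccc2Cl)c1COc1ccc(-c2nc3ccc(C(=O)O)cc3n2C2CCCCC2)cc1` gives 1450 nM. Compound 3 lies within the scatter of both neighbours: a 1.3-fold higher number from compound 1 to compound 3 (0.10 log units; within the scatter) and a 1.6-fold higher number from compound 2 to compound 3 (0.20 log units; within the scatter). Compound 4 `CC(C)c1onc(-c2c(Cl)cccc2Cl)c1COc1ccc(-c2nc3ccc(C(=O)O)cc3n2C2CCCC2)cc1` carries cyclopentyl in place of cyclohexyl on an aromatic nitrogen. For the measured compounds named here, the one step that bears on it is the ring-size step from compound 2 to compound 3, a 1.6-fold higher number from compound 2 to compound 3 (0.20 log units; within the scatter), which stayed within the scatter, as did the exchange of 4-fluorobenzyl for the saturated rings. No step beyond the scatter is therefore expected for compound 4, a 1.0-fold higher number from compound 3 to compound 4 (0.01 log units; within the scatter). Compound 4 is estimated at 1500 nM, with a range from 700 nM to 3200 nM.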

Compound 4, half-maximal inhibitory concentration: 929 nM
Compound 4: middle estimate off by 1.6-fold (0.21 log units), on the high side; measured number inside the range.
By their numbers in this assay, from the lowest: compounds 2, 4, 1 and 3 (each within the scatter of the next).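

In this assay cyclopentyl brings a third saturated ring size onto the aromatic nitrogen, and the steps stay small in both directions: a 1.6-fold lower number from compound 3 to compound 4 (0.19 log units; within the scatter) and a 1.0-fold higher number from compound 2 to compound 4 (0.00 log units; within the scatter) show no separation between the three rings. The exchange for the benzylic group gives the same picture, with a 1.2-fold lower number from compound 1 to compound 4 (0.09 log units; within the scatter) leaving all four compounds without a step beyond the scatter at this position. No evidence on hand accounts for this flat picture. Still open, from the compounds shown here alone, is whether a ring below cyclopentyl, such as cyclopropyl, or a group carrying an amine or a hydroxyl on this nitrogen would move the number beyond the scatter.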